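From Ethyl to Tert-Butyl on the Ring Nitrogen

A few compounds are considered here, and "the series" means these few. Any claim that something is new, unique, unknown or untested is made for them only; others in the source may bear on it.

Compound 2 `CCn1c(-c2cccnc2)nc2ccc(F)cc21` carries an ethyl group on a ring nitrogen of the shared core. In an assay on V79 cells for inhibition of cytochrome P450 11B1, mitochondrial (Homo sapiens), read by HTRF, with a stated time of 1 h (on this read-out lower numbers stand for stronger inhibition and higher numbers for weaker inhibition), compound 2 gives 2100 nM, the highest of the three measured numbers. Compound 1 `Fc1ccc2nc(-c3cccnc3)n(C3CC3)c2c1` gives 401 nM and compound 3 `Fc1cncc(-c2nc3cc(F)c(Cl)cc3n2C2CC2)c1` gives 251 nM. Compound 4 `CC(C)(C)n1c(-c2cccnc2)nc2ccc(F)cc21` differs from compound 2 by one change: tert-butyl in place of ethyl on an aromatic nitrogen. For the measured compounds named here, the only measured step at this position is a 5.2-fold higher number from compound 1 to compound 2 (0.72 log units; beyond the scatter), which concerns cyclopropyl against ethyl and says nothing directly about tert-butyl. Compound 4 is therefore expected to stay in the neighbourhood of compound 2. The estimated step of a 1.2-fold higher number from compound 2 to compound 4 (0.08 log units; within the scatter) is expected to lie within or only slightly beyond the scatter. The estimate for compound 4 is 2500 nM, in a range from 800 nM to 8000 nM.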

Compound 4, half-maximal inhibitory concentration: > 10000 nM
Compound 4: no number, only a limit; the forecaster's own chance of this, stated with the estimate: 5%; at least 4.0-fold (0.60 log units) between middle value and limit.
By their numbers in this assay, from the lowest: compounds 3 and 1 (each within the scatter of the next); then compound 2. At a limit, above all of these: compound 4.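

In this assay, compound 4 gives no number, only a limit: the limit of > 10000 nM in this assay, at which 1 of the 4 values shown sits. The change from ethyl to tert-butyl gives an at least 4.7-fold higher number from compound 2 to compound 4 (0.67 log units; beyond the scatter), and the change from cyclopropyl to tert-butyl gives an at least 24-fold higher number from compound 1 to compound 4 (1.39 log units; beyond the scatter). The earlier compounds shown here compared only ethyl and cyclopropyl on this aromatic nitrogen; tert-butyl now shows that this position does not treat all carbon groups alike.

On these data alone, how far compound 4 lies past its limit remains unknown. As far as these compounds go, whether a longer chain such as propyl, or a chain ending in an amine, would behave like ethyl or like tert-butyl also remains open.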